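Swapping fluoro for iodo on the pendant phenyl ring

The source may report more compounds than this note shows. Statements on the series, on what has been measured and on what is new or still open speak of the compounds shown alone.

Compound 1, `COc1cc(C(=O)c2sc(-c3ccc(F)cc3)cc2N)cc(OC)c1OC`, is measured in a functional assay on L1210 cells (Mus musculus) for antiproliferative activity (on this read-out higher numbers stand for weaker inhibition and lower numbers for stronger inhibition), and gives 20 nM. Among the three compounds measured, compound 1 stands second highest. Compound 3, `COc1cc(C(=O)c2sc(-c3cccc([N+](=O)[O-])c3)cc2N)cc(OC)c1OC`, gives 11 nM, and the change a 1.8-fold lower number from compound 1 to compound 3 (0.26 log units; within the scatter) is within the scatter. Compound 2, `COc1cc(C(=O)c2sc(-c3cc(OC)c(OC)c(OC)c3)cc2N)cc(OC)c1OC`, gives 2300 nM, a far higher number than compound 1.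

Compound 4, `COc1cc(C(=O)c2sc(-c3ccc(I)cc3)cc2N)cc(OC)c1OC`, differs from compound 1 by iodo in place of fluoro on an aromatic carbon. Going by the values given here, no measured step exchanges one halogen for another at this position. The step from compound 1 to compound 3 shows that replacing the whole pendant ring with a different small-substituted ring moves the number little, while compound 2 shows that a ring carrying three methoxy groups gives a much higher number. A single iodo is closer to the first case than the second, so in this assay a step for compound 4 of about a 1.5-fold higher number from compound 1 to compound 4 (0.18 log units; within the scatter) is expected, close to no change beyond the scatter. Compound 4 is therefore estimated at 30 nM, within 8 nM to 120 nM.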

Compound 4, half-maximal inhibitory concentration: 400 nM
Estimate against measurement, compound 4: 13-fold (1.12 log units) below; the measured number lies above the stated range.
By their numbers in this assay, from the lowest: compounds 3 and 1 (each within the scatter of the next); then compound 4; then compound 2.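

In this assay the exchange of one halogen for another at this place on the pendant ring is far from silent (a 20-fold higher number from compound 1 to compound 4 (1.30 log units; beyond the scatter)), even though each group is a single heavy atom with no hydrogen-bond donors or acceptors. The comparison with the nitro-bearing ring points the same way (a 36-fold higher number from compound 3 to compound 4 (1.56 log units; beyond the scatter)), so the small step between the 4-fluorophenyl and 3-nitrophenyl rings did not mean that this ring accepts any lightly substituted variant. Nothing measured here explains why iodo gives so much higher a number than fluoro.

The compounds shown leave open whether chloro or bromo at this place would sit nearer to fluoro or to iodo. They also leave open how a non-halogen group, such as a methyl group or an amine, would read at the same place.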